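Solubility notes: tetrahydronaphthalenyl amide replacing quinolin-8-yl amide

The source may hold more compounds than are shown below. What is called first, only, known or untested is meant among the compounds shown, and "the series" means these compounds.

Measured compounds:
compound 1 `COc1ccc(CC[C@@H](OC(=O)[C@@H]2CCCCN2C(=O)c2ccnc3ccccc23)c2cccc(OCC(=O)O)c2)cc1OC` — in a physicochemical assay for solubility (on this read-out higher numbers stand for higher solubility and lower numbers for lower solubility), compound 1 gives > 10000 nM, a limit of the assay.
compound 2 `COc1ccc(CC[C@@H](OC(=O)[C@@H]2CCCCN2C(=O)c2cccc3cccnc23)c2cccc(OCC(=O)O)c2)cc1OC` — in this assay compound 2 gives > 10000 nM, also a limit.

Compound 2 thus sits at the limit of > 10000 nM in this assay, at which 2 of the 2 values shown sit, with no number of its own. Among the measured compounds shown here, the single measured step, a step that the two limits leave unreadable from compound 1 to compound 2, is unreadable, both ends being limits, so nothing measured bears on the next change. Compound 3 `COc1ccc(CC[C@@H](OC(=O)[C@@H]2CCCCN2C(=O)[C@@H]2CCCc3ccccc32)c2cccc(OCC(=O)O)c2)cc1OC` differs from compound 2 by 1,2,3,4-tetrahydronaphthalen-1-yl in place of quinolin-8-yl on a carbonyl carbon. With no readable step available, compound 3 is expected to remain near the limit, with an estimated 10000 nM in a range of 3000 nM to 30000 nM. The expected step of a number no higher from compound 2 to compound 3 (the limit leaves the size open) is none beyond the scatter.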

Compound 3, solubility: > 10000 nM
Compound 3 gave a limit, no number (the forecaster's own chance of this, stated with the estimate: 65%); the middle value sits exactly at the limit.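

Steps among compound 1, compound 2 and compound 3 cannot be read, all three standing at a limit in this assay: the limit of > 10000 nM in this assay, at which 3 of the 3 values shown sit.
As far as these compounds go, how far the solubility of each compound lies past that limit, and whether quinolin-4-yl, quinolin-8-yl or 1,2,3,4-tetrahydronaphthalen-1-yl changes it, stays open.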